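A few compounds are considered here, and "the series" means these few. Any claim that something is new, unique, unknown or untested is made for them only; others in the source may bear on it.

In a functional assay on the whole organism for inhibition, with Cavia porcellus as the target (on this read-out lower numbers stand for an effect already at smaller amounts and higher numbers for an effect only at larger amounts of compound), compound 1 (`CCCn1c(=O)n(CCN(C)C)c(=O)c2[nH]cnc21`) gives 5.65 mg/kg while compound 2 (`CCCn1c(=O)n(CCCOC)c(=O)c2[nH]cnc21`) gives 0.72 mg/kg and compound 3 (`CCCn1c(=O)n(CCCCC(C)=O)c(=O)c2[nH]cnc21`) gives 2.55 mg/kg on the same core. Compound 3 thus holds the middle of the three numbers. The change to compound 4 (`CCCn1c(=O)n(C)c(=O)c2[nH]cnc21`) is hydrogen in place of 3-acetylpropyl on a saturated chain carbon bound to an aromatic nitrogen on a saturated chain carbon bound to an aromatic nitrogen. Two measured steps on this chain bear on it: a 2.2-fold lower number from compound 1 to compound 3 (0.35 log units; beyond the scatter) and a 3.5-fold higher number from compound 2 to compound 3 (0.55 log units; beyond the scatter) are modest and beyond the scatter, yet they run in opposite directions and neither removes the chain. In this assay no step beyond the scatter is therefore expected. The expected step is a 1.0-fold lower number from compound 3 to compound 4 (0.01 log units; within the scatter) with neither direction favoured. For compound 4 the estimated value is 2.5 mg/kg with an expected range from 0.7 mg/kg to 9 mg/kg as its upper end.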

Compound 4, dose for half-maximal effect: 4.44 mg/kg
Estimate against measurement, compound 4: 1.8-fold (0.25 log units) below; low and high end bracket the measured number.
By their numbers in this assay, from the lowest: compound 2; then compounds 3, 4 and 1 (each within the scatter of the next, the first and the last beyond it).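

In this assay, the chains of compound 3 and compound 1 prove separable from the plain methyl end of compound 4 by no more than the scatter (a 1.7-fold higher number from compound 3 to compound 4 (0.24 log units; within the scatter); a 1.3-fold lower number from compound 1 to compound 4 (0.10 log units; within the scatter)). Only the chain of compound 2 stands apart from it (a 6.2-fold higher number from compound 2 to compound 4 (0.79 log units; beyond the scatter)), so at this position a chain as such does not set the number, and what it adds rests on this single compound. Nothing available explains this difference.

Whether the gain holds for a longer ether chain remains open, since only one ether is shown. As far as these compounds go, a hydroxyl or a carboxylic acid at the chain end also remains untested here.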